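A few compounds are considered here, and "the series" means these few. Any claim that something is new, unique, unknown or untested is made for them only; others in the source may bear on it.

Of the compounds shown here, three have so far been measured in a physicochemical assay for solubility, read by HPLC, in phosphate buffer, with a stated time of 24 h, at pH 7.4, tested at 100 uM; on this read-out higher numbers stand for higher solubility and lower numbers for lower solubility. Compound 1 `Cc1ccc(Nc2c(NCCCCCC(=O)NO)c(=O)c2=O)cc1` gives 8100000 nM. Compound 2 `CN(C)c1ccc(Nc2c(NCCCCCC(=O)NO)c(=O)c2=O)cc1` gives 12000000 nM. Compound 3 `Cc1ccc(Nc2c(NC(C)CCCCC(=O)NO)c(=O)c2=O)cc1` gives 83000000 nM. The core of compound 2 differs from that of compound 1 by dimethylamino in place of methyl on an aromatic carbon, a change that made a 1.5-fold higher number from compound 1 to compound 2 (0.17 log units; within the scatter). Compound 3 differs from compound 1 by methyl in place of hydrogen on a saturated chain carbon bound to a nitrogen on an aromatic ring and a saturated chain carbon, a change that made a 10-fold higher number from compound 1 to compound 3 (1.01 log units; beyond the scatter). Compound 4 `C[C@H](CCCCC(=O)NO)Nc1c(Nc2ccc(N(C)C)cc2)c(=O)c1=O` has not yet been measured; it differs from compound 2 by methyl in place of hydrogen on a saturated chain carbon bound to a nitrogen on an aromatic ring and a saturated chain carbon, the same change at the same place, made here on the core of compound 2. A step of about an 8.3-fold higher number from compound 2 to compound 4 (0.92 log units; beyond the scatter) in this assay is expected, because the same change once gave a 10-fold higher number from compound 1 to compound 3 (1.01 log units; beyond the scatter). Compound 4 is therefore estimated at 100000000 nM, expected to lie between 40000000 nM and 250000000 nM, an expectation resting on a single earlier example.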

Compound 4, solubility: 80000000 nM
Compound 4: middle estimate off by 1.3-fold (0.10 log units), on the high side; the measured number falls inside the stated range.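

In this assay methyl in place of hydrogen on a saturated chain carbon bound to a nitrogen on an aromatic ring and a saturated chain carbon gave a 6.7-fold higher number from compound 2 to compound 4 (0.82 log units; beyond the scatter) in the same direction as a 10-fold higher number from compound 1 to compound 3 (1.01 log units; beyond the scatter) and both steps lie beyond the scatter. The change thus carried over from the core of compound 1 to the core of compound 2, but two cores differing in one group establish no general rule for the series. Nothing measured here explains why the number rises on either core.

The compounds shown leave open whether ethyl or a longer chain in place of the methyl would give a similar step. They also leave open whether the step holds with chloro or methoxy in place of dimethylamino on the aromatic carbon.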